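The source may report more compounds than this note shows. Statements on the series, on what has been measured and on what is new or still open speak of the compounds shown alone.

Measured compounds in a physicochemical assay for lipophilicity, measured as octanol-water partition; on this read-out lower numbers stand for lower lipophilicity and higher numbers for higher lipophilicity:
- compound 1 `Cc1ccc(-c2c(C#N)[n+]([O-])c3cc(C)ccc3[n+]2[O-])cc1`: 2.33
- compound 2 `COc1ccc(-c2c(C#N)[n+]([O-])c3cc(C)ccc3[n+]2[O-])cc1`: 1.83
- compound 3 `Cc1ccc(-c2c(C#N)[n+]([O-])c3cc(F)c(F)cc3[n+]2[O-])cc1`: 2.87

Compound 1 and compound 2 share one core and differ in a single place, (methoxy in place of methyl on an aromatic carbon). In this assay the step is a number 0.50 log units lower from compound 1 to compound 2 (beyond the scatter). Among the measured compounds shown here, compound 3 carries a different core; how the core of compound 3 differs from the core of compound 1 is not broken down here, and the two values show only that compound 3 sits higher than compound 1 and higher still than compound 2, both gaps beyond the scatter, so compound 3 has the highest number of the three measured.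

Compound 4 `COc1ccc(-c2c(C#N)[n+]([O-])c3cc(F)c(F)cc3[n+]2[O-])cc1` has not been measured in this assay. It stands to compound 3 as compound 2 stands to compound 1: the change is methoxy in place of methyl on an aromatic carbon, and the place of the change is the same in both pairs, so this is the same change made on the core of compound 3 rather than on the core of compound 1. For the measured compounds named here, the only guide to its size is the single earlier instance, the step from compound 1 to compound 2, which was modest and beyond the scatter. For the step from compound 3 to compound 4 a value of about a number 0.50 log units lower from compound 3 to compound 4 (beyond the scatter) is expected, resting on the step of a number 0.50 log units lower from compound 1 to compound 2 (beyond the scatter), with added uncertainty because the core is not the same.

Compound 4 is estimated at 2.37 in this assay, with the expected range running from 2.05 to 2.7.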

Compound 4, partition coefficient: 2.09
The estimate for compound 4 lay 0.28 log units above the measured number, within the range that was stated.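

In this assay, the change from 4-methylphenyl to 4-methoxyphenyl gives a number 0.78 log units lower from compound 3 to compound 4 (beyond the scatter), and on the other core it gave a number 0.50 log units lower from compound 1 to compound 2 (beyond the scatter), so the direction of the step held on both cores shown and each step stands clear of the usual scatter. Among the compounds shown here, this supports carrying the direction of this change between these two cores, and the printed sizes are similar but not equal; with only one pair on each core, it cannot be told whether that inequality belongs to the core or to ordinary variation between measurements, and no rule for the size of the step on any further core follows. No measurement on hand bears on why the step takes the size it does on either core.

The compounds shown leave open how an amine, a carboxylic acid or a longer chain such as butoxy would read in the same place, para to a large group, on either core. They also leave open whether the step keeps its direction on a core other than these two, or when the nitrile shared by all four compounds is replaced by an amide.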